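A few compounds are considered here, and "the series" means these few. Any claim that something is new, unique, unknown or untested is made for them only; others in the source may bear on it.

Working notes on the series. Three measured compounds share one core and differ only in the aryl group on the same aromatic carbon. Compound 1 `CC(=O)c1ccc(-c2cn3ccnc3c(-c3ccc4ncn(C5CCCCC5)c4c3)n2)cc1` carries 4-acetylphenyl there, and in a functional assay on NCI-H522 cells (Homo sapiens) for inhibition, read by sulforhodamine B assay, with a stated time of 48 h, tested at 10 uM (on this read-out lower numbers stand for less inhibition and higher numbers for more inhibition at the one concentration tested (going by the name of the read-out)), compound 1 gives 10.4%. Compound 2 `COc1ccccc1-c1cn2ccnc2c(-c2ccc3ncn(C4CCCCC4)c3c2)n1` carries 2-methoxyphenyl, and in this assay compound 2 gives 22.2%. Compound 3 `c1csc(-c2cn3ccnc3c(-c3ccc4ncn(C5CCCCC5)c4c3)n2)c1` carries thiophen-2-yl, and in this assay compound 3 gives 13.2%, the second highest of the three numbers; its nearest neighbour is compound 1, with a number 2.8 percentage points higher from compound 1 to compound 3 (within the scatter), and the wider gap within the scatter is a number 9 percentage points lower from compound 2 to compound 3 (within the scatter). Among the compounds with values here, only the step of a number 11.8 percentage points higher from compound 1 to compound 2 (beyond the scatter) lies beyond the scatter.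

Compound 4 `FC(F)(F)c1cccc(-c2cn3ccnc3c(-c3ccc4ncn(C5CCCCC5)c4c3)n2)c1` is the unmeasured member: 3-(trifluoromethyl)phenyl in place of thiophen-2-yl on an aromatic carbon. Within the data shown here, the steps that bear on this change are those swapping the aryl group on the same carbon: a number 2.8 percentage points higher from compound 1 to compound 3 (within the scatter) and a number 9 percentage points lower from compound 2 to compound 3 (within the scatter), both within the scatter, and a number 11.8 percentage points higher from compound 1 to compound 2 (beyond the scatter), modest. The three aryl groups measured so far keep the number in a narrow band at this concentration, so no step beyond the scatter is expected in this assay for compound 4, though a modest shift either way cannot be excluded. The expected step is a number 1.8 percentage points higher from compound 3 to compound 4 (within the scatter). Compound 4 is estimated at 15% in this assay, with a range from 3% to 32%.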

Compound 4, a percentage reported as inhibition, at one concentration (the size of the read-out at that concentration, not a potency): 10.7%
For compound 4 the middle estimate is 4.3 percentage points above the measured one; measured number inside the range.
By their numbers in this assay, from the lowest: compounds 1, 4, 3 and 2 (each within the scatter of the next, the first and the last beyond it).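

In this assay the six-membered, carbon-only ring bearing trifluoromethyl can take the place of the five-membered thiophen-2-yl ring with a number 2.5 percentage points lower from compound 3 to compound 4 (within the scatter) as the step, and set against 4-acetylphenyl it gives a number 0.3 percentage points higher from compound 1 to compound 4 (within the scatter) as the step, so neither swap can be told from repeat scatter. Against 2-methoxyphenyl the same group gives a number 11.5 percentage points lower from compound 2 to compound 4 (beyond the scatter) as a second step beyond the scatter at this carbon, which leaves compound 2 apart from compound 1 and compound 4 but not from compound 3, the one compound that goes against a clean separation. No measurement shown gives a reason for any of these steps.

Every compound shown carries an aromatic ring on this carbon, so what an amine or a carboxylic acid in the same place would do in this assay remains open. The readings also come from one concentration in one cell line, which leaves open whether these small steps would hold as differences in potency or in other cell lines.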